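Dropping a Fluoro Substituent: What to Expect in Rats

The compounds below may be only part of what the source reports. "The series", "measured", "known", "first", "only" and "open" are said of these compounds alone.

Of the compounds shown here, three have been tested in a functional assay on the whole organism for agonist activity, with Rattus norvegicus as the target; on this read-out higher numbers stand for an effect only at larger amounts of compound and lower numbers for an effect already at smaller amounts. Compound 1, `Fc1cccc2c1CC2CN1CCN(c2cccc3c2OCCO3)CC1`, reaches only a limit in this assay: compound 1 gives > 10 mg/kg. Compound 2, `C1=C(CCN2CCN(c3cccc4c3OCCO4)CC2)c2ccccc2C1`, likewise stops at a limit, and compound 2 gives > 2.5 mg/kg. Compound 3, `COc1cc2c(cc1OC)C(CCN1CCN(c3cccc4c3OCCO4)CC1)CC2`, also ends at a limit, where compound 3 gives > 40 mg/kg. Going by the values given here, each of the three thus sits at a limit, (the limit of > 10 mg/kg in this assay, at which 1 of the 3 values shown sits), the limit of > 2.5 mg/kg in this assay, at which 1 of the 3 values shown sits, or (the limit of > 40 mg/kg in this assay, at which 1 of the 3 values shown sits), and no step between measured compounds can be sized. Compound 4, `c1ccc2c(c1)CC2CN1CCN(c2cccc3c2OCCO3)CC1`, differs from compound 1 by hydrogen in place of fluoro on an aromatic carbon. Among the compounds with values here, no measured step gives a direction, so the step is expected to stay within the scatter, a number no higher from compound 1 to compound 4 (the limit leaves the size open). Compound 4 is estimated at 10 mg/kg, between 3 mg/kg and 40 mg/kg, most likely again only a limit.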

Compound 4, minimum effective dose: 10 mg/kg
The estimate for compound 4 equals the measured number at the digits printed, and the stated range covers the measured number.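

In this assay compound 4 gives an actual number, the first among the compounds shown, while the other three stop at limits. For hydrogen in place of fluoro on this aromatic carbon, the record is a number no higher from compound 1 to compound 4 (the limit leaves the size open) and no more than that. The size of this step cannot be read because compound 1 gives only a limit: the limit of > 10 mg/kg in this assay, at which 1 of the 4 values shown sits.

On these data alone, what stays open is how a chloro or a methoxy group on the same aromatic carbon would compare with hydrogen. The compounds shown also leave open whether fluoro makes any difference here.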